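Lengthening the Diamine Chain in Terpenoid Amines

The source may report more compounds than this note shows. Statements on the series, on what has been measured and on what is new or still open speak of the compounds shown alone.

Compound 1 `CC(C)=CCCC(C)=CCNCCN` and compound 2 `CC(C)=CCCC(C)=CCNCCCN` share a core and differ in one place: aminomethyl in place of amino on a saturated chain carbon, two bonds along the chain from an amine nitrogen. In a toxicity assay on CHO cells (Cricetulus griseus) for cytotoxicity, read by WST assay, with a stated time of 24 h (a higher number here means a weaker inhibitor, a lower number a stronger inhibitor), compound 1 gives 36200 nM. Compound 2 reaches only a limit of this assay, > 150000 nM, so no number is known for it. The step was therefore an at least 4.1-fold higher number from compound 1 to compound 2 (0.61 log units; beyond the scatter), and its size is only a lower bound because of the limit of > 150000 nM in this assay, at which 1 of the 3 values shown sits.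

Compound 3 `CC(C)=CCC/C(C)=C\CCC(C)=CCNCCCCN` has a different core; the difference between the cores of compound 1 and compound 3 is not broken down here. In this assay compound 3 gives 18100 nM, which lies within the scatter of compound 1.

Compound 4 `CC(C)=CCC/C(C)=C\CCC(C)=CCNCCCCCN` differs from compound 3 by aminomethyl in place of amino on a saturated chain carbon, four bonds along the chain from an amine nitrogen. This is the same kind of change as that from compound 1 to compound 2, but the place differs: there the saturated chain carbon sits two bonds along the chain from an amine nitrogen, here four bonds along the chain from an amine nitrogen. For compound 4 the expected step is a 2.2-fold higher number from compound 3 to compound 4 (0.34 log units; beyond the scatter), resting on the earlier step of an at least 4.1-fold higher number from compound 1 to compound 2 (0.61 log units; beyond the scatter), with the longer chain tempering confidence. Compound 4 is estimated at 40000 nM, expected between 15000 nM and 150000 nM.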

Compound 4, half-maximal inhibitory concentration: 38400 nM
Compound 4: middle estimate off by 1.0-fold (0.02 log units), on the high side; the measured number falls inside the stated range.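

Putting aminomethyl in place of amino gave a higher number in this assay on both cores, and the new step is a 2.1-fold higher number from compound 3 to compound 4 (0.33 log units; beyond the scatter). The direction of the change therefore carried from the core of compound 1 to the core of compound 3, even though the changed carbon sits at a different place along the chain in each pair: the same change on two cores in this assay, an at least 4.1-fold higher number (0.61 log units; beyond the scatter) from compound 1 to compound 2 and a 2.1-fold higher number (0.33 log units; beyond the scatter) from compound 3 to compound 4; the limit leaves it open whether they differ. This does not show that the step has the same size on both cores, because compound 2 gives a limit and not a number: the limit of > 150000 nM in this assay, at which 1 of the 4 values shown sits.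

Among the compounds shown here, with only two pairs, a general rule for this series is not established. The compounds shown leave open whether a still longer chain would raise the number further in this assay, and how a second amine on the chain or a carboxylic acid in place of the amine at its end would behave on either core.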